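A few compounds are considered here, and "the series" means these few. Any claim that something is new, unique, unknown or untested is made for them only; others in the source may bear on it.

Notes on the series, so far two compounds at the same reading. In an ADME assay on HEK-293T cells (Homo sapiens) for cytotoxicity, read by MTT assay, with a stated time of 48 h (a higher number here means that more compound is tolerated, a lower number that less compound is tolerated), compound 1 `Cn1cc(C2CC(c3ccc(F)cc3)=NN2C(=O)c2cccnc2)c2cc(Br)ccc21` gives > 300000 nM and this is a limit of the assay, not a number. Compound 2 `COc1ccc2c(c1)c(C1CC(c3ccc(Cl)cc3)=NN1C(=O)c1ccc(OC)nc1)cn2C` gives > 300000 nM and this too is a limit, not a number. Compound 2 therefore stands on the limit of > 300000 nM in this assay, at which 2 of the 2 values shown sit, and has no numeric value of its own.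

Compound 3 `COc1cccc(C2=NN(C(=O)c3ccc(OC)nc3)C(c3cn(C)c4ccc(OC)cc34)C2)c1` keeps the shared core of compound 2 and changes one place: 3-methoxyphenyl in place of 4-chlorophenyl on a carbon with a double bond to nitrogen. Among the measured compounds shown here, no measured pair differs in one place only, so the data give no size for any single change.

The expectation for compound 3 rests on compound 2 with its limit of > 300000 nM as the only close reference. Expected in this assay is a number no higher from compound 2 to compound 3 (the limit leaves the size open) with no shift beyond the scatter and no favoured direction. For compound 3 the estimated value is 300000 nM with an expected range from 120000 nM to 600000 nM and the assay may well report only a limit again.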

Compound 3, half-maximal cytotoxic concentration: > 300000 nM
Compound 3 was reported as a limit; the forecaster's own chance of this, stated with the estimate: 75%; the middle value sits exactly at the limit.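

Compound 2 and compound 3 are both reported only as limits of the assay, so no step can be read between them, and the change from 4-chlorophenyl to 3-methoxyphenyl has no readable size. The compounds shown leave open whether any single change on the shared core moves the result in this assay, since all that is on hand is one reading: the limit of > 300000 nM in this assay, at which 3 of the 3 values shown sit.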